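Swapping the Aryl Group on a Shared Core

The source may report more compounds than this note shows. Statements on the series, on what has been measured and on what is new or still open speak of the compounds shown alone.

Measured compounds:
compound 1, `O=C1N=C(C2C(=O)c3ccccc3C2=O)CC(c2ccc([N+](=O)[O-])cc2)N1`: 16%
compound 2, `O=C1N=C(C2C(=O)c3ccccc3C2=O)CC(c2ccc(Cl)cc2)N1`: 15%

Both compounds were tested in a functional assay on the whole organism for inhibition, with Rattus norvegicus as the target, read by paw edema, with stated times of 30 min and 1 h, at a dose of 10 mg/kg by the oral route; on this read-out higher numbers stand for more inhibition at the one dose given (going by the name of the read-out) and lower numbers for less inhibition. Among the compounds with values here, on this read-out compound 2 gives 15%, which is the lower of the two numbers, yet its only neighbour, compound 1, sits within the scatter of it, so the two cannot be ranked. Within the data shown here, the one step measured so far, a number 1 percentage points lower from compound 1 to compound 2 (within the scatter), changed a group on the same aromatic ring that is now altered again and made no difference beyond the scatter.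

Compound 3, `O=C1N=C(C2C(=O)c3ccccc3C2=O)CC(c2ccccc2O)N1`, is not yet measured. It differs from compound 2 by 2-hydroxyphenyl in place of 4-chlorophenyl on a saturated ring carbon. Among the measured compounds shown here, the single known step touches the same ring and was flat, but it does not involve a hydroxy group or a change in where the substituent sits on that ring, so it bears on the new change only loosely. With nothing pointing to a shift, the expectation is for a step of about a number 1 percentage points higher from compound 2 to compound 3 (within the scatter), that is, none beyond the scatter. Compound 3 is therefore estimated at 16%, within the range 4% to 30%.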

Compound 3, a percentage reported as inhibition, in the whole organism at one dose (the size of the read-out at that dose, not a potency): 24%
The estimate for compound 3 lay 8 percentage points below the measured number; measured number inside the range.
By their numbers in this assay, from the lowest: compounds 2, 1 and 3 (each within the scatter of the next).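

Within the data shown here, this is the first change at this saturated ring carbon that brings in a hydrogen-bond donor and also moves the substituent to another place on the aromatic ring, and in this assay it still stays inside the usual noise. It appears as a number 9 percentage points higher from compound 2 to compound 3 (within the scatter) and, measured against the nitro compound, as a number 8 percentage points higher from compound 1 to compound 3 (within the scatter), so the 4-nitrophenyl, 4-chlorophenyl and 2-hydroxyphenyl groups cannot be ranked, and this read-out at a single dose does not yet separate any of the three. No measurement is available here that could explain the reading of compound 3.

The names 4-chlorophenyl and 2-hydroxyphenyl differ in both the substituent and its place on the ring, so these compounds cannot show which of the two matters, or whether either does. From the compounds shown here alone, it also remains open whether an aminophenyl group, a carboxylic acid or a longer alkyl chain on this same ring carbon would give a number that stands clearly apart from the three seen so far.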